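This account rests on a few compounds, and the source may have more. Where it says the series, first, only, none or still open, it means among the compounds named here.

Measured in a toxicity assay on the whole organism with Rattus norvegicus as the target, at a dose of 200 mg/kg by the oral route; a higher number here means a stronger effect of the compound at the dose given, a lower number a weaker effect:
compound 1 `Clc1ccc(OCC2=NCCO2)cc1` gives 60%
compound 2 `Cc1cc(OCC2=NCCO2)ccc1Cl` gives 70%

Going by the values given here, on these two numbers compound 2 stands highest, with compound 1 nearest, and the only measured step, a number 10 percentage points higher from compound 1 to compound 2 (within the scatter), lies within the scatter. Compound 3 `Cc1cccc(OCC2=NCCO2)c1` differs from compound 2 by hydrogen in place of chloro on an aromatic carbon. Among the compounds with values here, the measured step concerns methyl in place of hydrogen, not hydrogen in place of chloro, so no measured step bears on this change. The step in this assay is therefore expected to be small, a number 10 percentage points lower from compound 2 to compound 3 (within the scatter), in no clear direction. Compound 3 is estimated at 60%, within 40% to 80%.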

Compound 3, a percentage reported as activity, at one dose (the size of the read-out at that dose, not a potency): 70%
Beside the measured number, compound 3's estimate is 10 percentage points below it, and the stated range covers the measured number.
By their numbers in this assay, from the lowest: compounds 1, 2 and 3 (each within the scatter of the next).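

Compound 3 is the first compound shown without chloro, and in this assay hydrogen in place of chloro gives no change at the digits printed from compound 2 to compound 3 (within the scatter) at this position ortho to a methyl group. With that methyl group present, chloro at this position is therefore not required for a read-out of this size at this dose. Nothing measured here offers an explanation for this result. On these data alone, whether a fluoro or methoxy group or an amine at this position would also stay within the scatter remains open. So does the effect of a longer chain in place of the methyl group.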